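The source may hold more compounds than are shown below. What is called first, only, known or untested is meant among the compounds shown, and "the series" means these compounds.

Compound 1 `O=C(Nc1cccc(-n2cc(-c3ccncc3)c(-c3cc(O)cc(Cl)c3)n2)c1)Nc1ccc(Cl)c(C(F)(F)F)c1`: 102%
Compound 2 `O=C(Nc1cccc(-n2cc(-c3ccncc3)c(-c3cc(O)cc(Cl)c3)n2)c1)Nc1ccc(Cl)c(Cl)c1`: 100%
Compound 3 `COc1cc(Cl)cc(-c2nn(-c3cccc(NC(=O)Nc4ccc(Cl)c(C(F)(F)F)c4)c3)cc2-c2ccncc2)c1`: 98%

In a functional assay on CAKI-1 cells (Homo sapiens) for inhibition, read by sulforhodamine B assay, with a stated time of 48 h, tested at 0.01 uM (a lower number here means a stronger effect, a higher number a weaker effect of the compound at the concentration tested), compound 3 gives 98%. On the numbers shown, compound 3 sits at the low end of the three, but the gaps to compound 2 and compound 1 are within the scatter of repeated measurements, as the step of a number 4 percentage points lower from compound 1 to compound 3 (within the scatter) makes clear. The three measured compounds therefore read as a single group with no separation between them.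

Compound 4 `COc1cc(Cl)cc(-c2nn(-c3cccc(NC(=O)Nc4ccc(Cl)c(Cl)c4)c3)cc2-c2ccncc2)c1` is not yet measured. It is reached from compound 3 by the change (chloro in place of trifluoromethyl on an aromatic carbon). The same change has been measured once before, on the pair with hydrogen on the ring oxygen, as the step of a number 2 percentage points lower from compound 1 to compound 2 (within the scatter). That step is within the scatter, and the step of a number 4 percentage points lower from compound 1 to compound 3 (within the scatter) shows that the methyl on the oxygen did not move the number either. From this one precedent compound 4 is expected to show a step of a number 1 percentage points lower from compound 3 to compound 4 (within the scatter) in this assay, that is, no movement beyond the scatter. Compound 4 is estimated at 97%, with a range from 88% to 106%.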

Compound 4, a percentage reported as activity, at one concentration (the size of the read-out at that concentration, not a potency): 96%
The estimate for compound 4 lay 1 percentage points above the measured number; measured number inside the range.
By their numbers in this assay, from the lowest: compounds 4, 3, 2 and 1 (each within the scatter of the next).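

In this assay, the change from trifluoromethyl to chloro, earlier seen only on the core with hydrogen on the ring oxygen, now also stands on the core with methyl there, as a number 2 percentage points lower from compound 3 to compound 4 (within the scatter), and the two readings agree: the same change on two cores in this assay, a number 2 percentage points lower (within the scatter) from compound 1 to compound 2 and a number 2 percentage points lower (within the scatter) from compound 3 to compound 4, 0 percentage points apart, within the scatter of two such steps

The methyl on the ring oxygen has likewise now been read with the 3,4-dichlorophenyl group as well as with the 4-chloro-3-(trifluoromethyl)phenyl group, as a number 4 percentage points lower from compound 2 to compound 4 (within the scatter): the same change on two cores in this assay, a number 4 percentage points lower (within the scatter) from compound 1 to compound 3 and a number 4 percentage points lower (within the scatter) from compound 2 to compound 4, 0 percentage points apart, within the scatter of two such steps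

Neither change therefore moves the number beyond the scatter on either core.

With all four compounds inside the scatter of one another, the set does not show whether this position can affect the read-out at all at the concentration tested. Going by these compounds, whether an amine or a carboxylic acid in place of the chloro would shift the number remains open.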